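Swapping the aryl group at the ring-oxygen side of the chromone

The source may hold more compounds than are shown below. What is called first, only, known or untested is meant among the compounds shown, and "the series" means these compounds.

Of the compounds shown here, two have been tested in an assay on isolated protein (Cavia porcellus) with Sigma non-opioid intracellular receptor 1 (Homo sapiens) as the target, read by radioligand binding; on this read-out lower numbers stand for stronger inhibition and higher numbers for weaker inhibition. Compound 1 `O=c1cc(-c2cccs2)oc2ccc(OCCCCCCN3CCC(O)CC3)cc12` carries a thiophen-2-yl group on the shared core, and in this assay compound 1 gives 232 nM. Compound 2 `COc1cccc(-c2cc(=O)c3cc(OCCCCCCN4CCC(O)CC4)ccc3o2)c1` carries a 3-methoxyphenyl group at the same position, and in this assay compound 2 gives 111 nM. Within the data shown here, of the two numbers, compound 2 stands at the lowest, and the only measured step, a 2.1-fold lower number from compound 1 to compound 2 (0.32 log units; beyond the scatter), describes how far it lies from compound 1.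

Compound 3 `O=c1cc(-c2cccnc2)oc2ccc(OCCCCCCN3CCC(O)CC3)cc12` has not yet been measured. The change from compound 2 to compound 3 is pyridin-3-yl in place of 3-methoxyphenyl on an aromatic carbon. Among the measured compounds shown here, no measured step covers this exact exchange; the one step known, from a thiophen-2-yl to a 3-methoxyphenyl, shows that a modest shift can follow a change of the aryl group at this position, but it does not tell which way a pyridin-3-yl will move the number. The estimate for compound 3 in this assay is therefore a modest weakening, a 2.3-fold higher number from compound 2 to compound 3 (0.35 log units; beyond the scatter), giving an expected value of 250 nM with a range from 100 nM to 600 nM.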

Compound 3, half-maximal inhibitory concentration: 210 nM
The estimate for compound 3 lay 1.2-fold (0.08 log units) above the measured number, within the range that was stated.
By their numbers in this assay, from the lowest: compounds 2, 3 and 1 (each within the scatter of the next, the first and the last beyond it).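

Placing a pyridin-3-yl group on this aromatic carbon gives a 1.9-fold higher number from compound 2 to compound 3 (0.28 log units; within the scatter) in this assay, and from the other side a 1.1-fold lower number from compound 1 to compound 3 (0.04 log units; within the scatter), so neither step can be told apart from the ordinary spread of repeated measurements. Compound 3 therefore cannot be grouped with either earlier compound, and the only separation at this position remains a 2.1-fold lower number from compound 1 to compound 2 (0.32 log units; beyond the scatter). What is new is that an aromatic ring holding a nitrogen, with 6 heavy atoms in place of the 8 of 3-methoxyphenyl, can stand at this place next to the ring oxygen without a step beyond the scatter from either neighbour.

The exchange from 3-methoxyphenyl to pyridin-3-yl removes the methoxy group and brings in the ring nitrogen at once, so the two changes cannot be separated here, and a plain phenyl group would be the missing link between them. Whether a non-aromatic ring such as cyclohexyl, or a phenyl ring carrying an amine or a carboxylic acid, would stay as close at this position remains open, and no evidence on the cause of these numbers is at hand.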